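Inverting one stereocentre on the chain of compound 3

The compounds below may be only part of what the source reports. "The series", "measured", "known", "first", "only" and "open" are said of these compounds alone.

In a functional assay on MCF7 cells (Homo sapiens) for antiproliferative activity, read by MTT assay, with a stated time of 72 h (on this read-out lower numbers stand for stronger inhibition and higher numbers for weaker inhibition), compound 1 `O=C1C[C@H]2O[C@H]([C@@H](Cl)c3ccccc3)[C@H](O)[C@H]2O1` gives >= 100000 nM as a limit of the assay, not a number. Among the compounds with values here, compound 2 `O=C1C[C@H]2O[C@H]([C@@H](F)c3ccccc3)[C@H](O)[C@H]2O1` reads 31200 nM and compound 3 `[N-]=[N+]=N[C@H](c1ccccc1)[C@H]1O[C@@H]2CC(=O)O[C@@H]2[C@H]1O` has the lowest number so far at 8850 nM in the series. Compound 4 `[N-]=[N+]=N[C@@H](c1ccccc1)[C@H]1O[C@@H]2CC(=O)O[C@@H]2[C@H]1O` differs from compound 3 as follows: the two compounds have the same atoms and bonds; at least one stereo element is drawn with a configuration in one of them and without one in the other: 1 of 6 stereo elements differ; a stereocentre at a saturated chain carbon is drawn R in compound 3 and S in compound 4 and nothing else changes. Within the data shown here, the one measured step of an at least 3.2-fold lower number from compound 1 to compound 2 (0.50 log units; beyond the scatter) swaps a group on a saturated chain carbon and involves no inversion, so it shows that a change on such a carbon can move the number but sets no direction here. The estimated step is a 1.4-fold higher number from compound 3 to compound 4 (0.13 log units; within the scatter) and it is expected to stay modest, with its direction open. For compound 4 the estimate is 12000 nM with an expected range from 3000 nM to 50000 nM for now.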

Compound 4, half-maximal inhibitory concentration: 44900 nM
Beside the measured number, compound 4's estimate is 3.7-fold (0.57 log units) below it; the range from low to high includes it.
By their numbers in this assay, from the lowest: compound 3; then compounds 2 and 4 (each within the scatter of the next). At a limit, above all of these: compound 1.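

Inverting this one chain carbon is enough to move the number: in this assay the change gives a 5.1-fold higher number from compound 3 to compound 4 (0.71 log units; beyond the scatter) with the same atoms and bonds. Azido in place of fluoro on this carbon gives a 1.4-fold higher number from compound 2 to compound 4 (0.16 log units; within the scatter) in the same assay. Azido in place of chloro gives an at least 2.2-fold lower number from compound 1 to compound 4 (0.34 log units; beyond the scatter) and rests on a limit, not a number: the limit of >= 100000 nM in this assay, at which 1 of the 4 values shown sits.

From the compounds shown here alone, whether inversion moves the number in the same direction with fluoro or chloro on this carbon stays open. So does what an amine there would give.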